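The source may hold more compounds than are shown below. What is called first, only, known or untested is meant among the compounds shown, and "the series" means these compounds.

Compound 1 `O=C(/C=C/c1ccc([N+](=O)[O-])cc1)Nc1cc2c(Nc3ccc(F)c(Cl)c3)ncnc2cc1O[C@H]1CCOC1` stands highest of the two numbers measured in a functional assay on PC-3 cells (Homo sapiens) for cytotoxicity, read by MTT assay, with a stated time of 72 h (on this read-out higher numbers stand for weaker inhibition and lower numbers for stronger inhibition), where compound 1 gives 22800 nM. Compound 2 `COc1cc(/C=C/C(=O)Nc2cc3c(Nc4ccc(F)c(Cl)c4)ncnc3cc2O[C@H]2CCOC2)cc(OC)c1OC` gives 20500 nM in this assay, and the step of a 1.1-fold lower number from compound 1 to compound 2 (0.05 log units; within the scatter) shows that swapping the group on this ring barely moved the number. Compound 3 `COc1ccc(/C=C/C(=O)Nc2cc3c(Nc4ccc(F)c(Cl)c4)ncnc3cc2O[C@H]2CCOC2)cc1` differs from compound 1 by methoxy in place of nitro on an aromatic carbon, a change at the same ring. For the measured compounds named here, only that one step bears on it, and it lay within the scatter, so no step beyond the scatter is expected in this assay: for compound 3 the estimate is 21000 nM, between 10000 nM and 45000 nM, a step of a 1.1-fold lower number from compound 1 to compound 3 (0.04 log units; within the scatter).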

Compound 3, half-maximal inhibitory concentration: 2240 nM
Compound 3: middle estimate off by 9.4-fold (0.97 log units), on the high side; measured number below the stated range.
By their numbers in this assay, from the lowest: compound 3; then compounds 2 and 1 (each within the scatter of the next).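

In this assay, the group on this ring matters after all, although the first two compounds suggested otherwise: methoxy in place of nitro gives a 10-fold lower number from compound 1 to compound 3 (1.01 log units; beyond the scatter). A methoxy group on that carbon is not enough by itself, since 4-methoxyphenyl in place of 3,4,5-trimethoxyphenyl gives a 9.2-fold lower number from compound 2 to compound 3 (0.96 log units; beyond the scatter). Nothing available explains either step. As far as these compounds go, it remains open whether the gain is specific to methoxy, which a hydroxyl, an ethoxy or an amine on the same carbon would help to show.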